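A few compounds are considered here, and "the series" means these few. Any claim that something is new, unique, unknown or untested is made for them only; others in the source may bear on it.

Compound 1 `COc1cc(-c2nn(-c3cccc(NC(=O)Nc4cc(C(F)(F)F)cc(C(F)(F)F)c4)c3)cc2-c2ccncc2)ccc1Cl`: in a functional assay on RPMI-8226 cells (Homo sapiens) for inhibition, read by sulforhodamine B assay, with a stated time of 48 h (a lower number here means that less compound is tolerated, a higher number that more compound is tolerated), compound 1 gives > 50000 nM, which is a limit of the assay and not a number.
Compound 2 `O=C(Nc1cccc(-n2cc(-c3ccncc3)c(-c3ccc(Cl)c(O)c3)n2)c1)Nc1cc(C(F)(F)F)cc(C(F)(F)F)c1`: in this assay compound 2 gives > 50000 nM, again only a limit.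
Compound 3 `COc1cc(-c2nn(-c3cccc(NC(=O)Nc4ccc(Cl)c(C(F)(F)F)c4)c3)cc2-c2ccncc2)ccc1Cl`: in this assay compound 3 gives > 32500 nM, also a limit.

Compound 2 differs from compound 1 by hydrogen in place of methyl on an oxygen on an aromatic ring. The step that the two limits leave unreadable from compound 1 to compound 2 cannot be read because the limit of > 50000 nM in this assay, at which 2 of the 3 values shown sit, marks where both compounds sit, so nothing is known about how large this change is.

Compound 4 `O=C(Nc1cccc(-n2cc(-c3ccncc3)c(-c3ccc(Cl)c(O)c3)n2)c1)Nc1ccc(Cl)c(C(F)(F)F)c1` has not been measured. It differs from compound 3 by hydrogen in place of methyl on an oxygen on an aromatic ring, the same change at the same place as that from compound 1 to compound 2. The difference between the core of compound 3 and the core of compound 1 is not broken down here.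

Since compound 3 sits at the limit of > 32500 nM in this assay, at which 1 of the 3 values shown sits, and compound 1 at the limit of > 50000 nM in this assay, at which 2 of the 3 values shown sit, the expected step that the limit leaves unreadable from compound 3 to compound 4 from compound 3 to compound 4 is taken as essentially flat, with the value most likely again reported as a limit. Compound 4 is therefore estimated at 60000 nM, with a range from 30000 nM to 200000 nM.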

Compound 4, concentration lethal to 50% of the cells: > 32500 nM
Compound 4 gave a limit, no number (the forecaster's own chance of this, stated with the estimate: 85%); the middle value is on the limit's open side.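

Compound 3 and compound 4 both give only a limit and not a number, so the step from methoxy to hydroxy between them cannot be read: the limit of > 32500 nM in this assay, at which 2 of the 4 values shown sit.

The compounds shown leave open what the lethal concentration of any of the four is in this assay, and whether the change from methoxy to hydroxy makes any difference there.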